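The compounds below may be only part of what the source reports. "The series", "measured", "known", "first", "only" and "open" are said of these compounds alone.

Measured so far in a physicochemical assay for lipophilicity, measured as octanol-water partition; a higher number here means a more lipophilic compound, a lower number a more polar compound:
- compound 1 `CC1=C(C(=O)OCc2ccccn2)C(c2cccc(O)c2)C2=C(CCCC2=O)N1` gives 1.58
- compound 2 `CC1=C(C(=O)OCc2cccnc2)C(c2cccc(O)c2)C2=C(CCCC2=O)N1` gives 1.21

Compound 2 holds the lower of these two numbers, and its gap to compound 1 is beyond the scatter. Compound 3 `COc1ccc(C2C(C(=O)OCc3cccnc3)=C(C)NC3=C2C(=O)CCC3)cc1` carries 4-methoxyphenyl in place of 3-hydroxyphenyl on a saturated ring carbon. Among the measured compounds shown here, the one measured step of a number 0.37 log units lower from compound 1 to compound 2 (beyond the scatter) sits elsewhere in the molecule, so it offers only a rough sense of size. For the measured compounds named here, no measured step touches this ring carbon, and the expected upward direction rests on the counted difference alone. In this assay the expected step is larger than that one, estimated as a number 0.69 log units higher from compound 2 to compound 3 (beyond the scatter) here. Compound 3 is expected at 1.9 with an estimated range (1.5 to 2.4).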

Compound 3, partition coefficient: 1.54
Beside the measured number, compound 3's estimate is 0.36 log units above it; the range from low to high includes it.
By their numbers in this assay, from the lowest: compound 2; then compounds 3 and 1 (each within the scatter of the next).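

This position on the saturated ring carbon also moves the number in this assay: 4-methoxyphenyl in place of 3-hydroxyphenyl gives a number 0.33 log units higher from compound 2 to compound 3 (beyond the scatter). The swap changes the substituent, its place on the phenyl ring and the count of hydrogen-bond donors together, so this single step cannot assign the shift to any one of these differences. Nothing measured here explains the step. Open questions are how 4-hydroxyphenyl or 3-methoxyphenyl would separate those differences, and how an amine or a carboxylic acid on this phenyl ring would read in this assay.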